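From a cyclohexyl amine to a methylpiperidine on the oxygen

This account rests on a few compounds, and the source may have more. Where it says the series, first, only, none or still open, it means among the compounds named here.

In an ADME assay on microsomes from liver (Rattus norvegicus) for metabolic stability, read by HPLC, using NADPH, with stated times of 5 min and 60 min, tested at 10 uM (on this read-out lower numbers stand for slow clearance and higher numbers for fast clearance), compound 1 `CCS(=O)(=O)Nc1ccc(Oc2ccccc2)c(-c2cn(C)c(=O)c3[nH]ccc23)c1`, with a phenyl on an oxygen on an aromatic ring, gives 3330 mL/min/kg. Compound 2 `CCS(=O)(=O)Nc1ccc(Oc2ccc(C#N)cc2)c(-c2cn(C)c(=O)c3[nH]ccc23)c1`, which adds a cyano group to that phenyl, gives 81.7 mL/min/kg. That is a 41-fold lower number from compound 1 to compound 2 (1.61 log units; beyond the scatter).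

Compound 3 `CCS(=O)(=O)Nc1ccc(OC2CCC(N(C)C)CC2)c(-c2cn(C)c(=O)c3[nH]ccc23)c1` gives < 45 mL/min/kg, which is a limit of the assay and not a number. All that is known of its place is the limit of < 45 mL/min/kg in this assay, at which 1 of the 3 values shown sits. Putting 4-(dimethylamino)cyclohexyl on the oxygen produced an at least 74-fold lower number from compound 1 to compound 3 (1.86 log units; beyond the scatter). Against the cyano compound, the comparison reads an at least 1.8-fold lower number from compound 2 to compound 3 (0.25 log units; that floor lies within the scatter).

Compound 4 `CCS(=O)(=O)Nc1ccc(OC2CCN(C)CC2)c(-c2cn(C)c(=O)c3[nH]ccc23)c1` keeps the shared core but carries 1-methylpiperidin-4-yl in place of 4-(dimethylamino)cyclohexyl on an oxygen on an aromatic ring. Within the data shown here, no measured step makes this exact swap, so the nearest guide is the step to compound 3, an at least 74-fold lower number from compound 1 to compound 3 (1.86 log units; beyond the scatter), where a non-aromatic ring replaced the phenyl. Compound 4 also has a six-membered non-aromatic ring on the oxygen, so it is expected to stay close to compound 3. The expected outcome is no change beyond the scatter, an estimated a number no lower from compound 3 to compound 4 (the limit leaves the size open). For compound 4 the estimated clearance is 45 mL/min/kg, with an expected range from 25 mL/min/kg to 100 mL/min/kg.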

Compound 4, clearance: 80 mL/min/kg
For compound 4 the middle estimate is 1.8-fold (0.25 log units) below the measured one; measured number inside the range.
By their numbers in this assay, from the lowest: compounds 4 and 2 (each within the scatter of the next); then compound 1. At a limit, below all of these: compound 3.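

Replacing the phenyl with 1-methylpiperidin-4-yl gives a 42-fold lower number from compound 1 to compound 4 (1.62 log units; beyond the scatter) in this assay, so the large drop on this read-out is not tied to the 4-(dimethylamino)cyclohexyl group alone. Against the aromatic nitrile, the same group gives a 1.0-fold lower number from compound 2 to compound 4 (0.01 log units; within the scatter), which means that 1-methylpiperidin-4-yl and 4-cyanophenyl cannot be told apart here, even though one is a non-aromatic ring with a nitrogen and the other an aromatic ring with a cyano group. The swap between the two amine-bearing rings reads an at least 1.7-fold higher number from compound 3 to compound 4 (0.24 log units; that floor lies within the scatter), and it rests on a limit of the assay and not a number, so no real difference between these two groups can be claimed: the limit of < 45 mL/min/kg in this assay, at which 1 of the 4 values shown sits.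

As far as these compounds go, what a plain cyclohexyl with no amine would give on the oxygen remains open, so the part played by the ring and the part played by its nitrogen cannot yet be separated. Also open, from the compounds shown here alone, is whether a piperidine with hydrogen in place of the methyl on its nitrogen, or a morpholine ring, would fall in the same range.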